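Aryl amine swap on the urea series

A few compounds are considered here, and "the series" means these few. Any claim that something is new, unique, unknown or untested is made for them only; others in the source may bear on it.

Among the compounds with values here, compound 3 `COc1cc(NC(=O)Nc2cc(Nc3cc(I)ccc3OC)ncn2)cc(OC)c1` holds the highest reading of the three compounds measured so far: in a functional assay on NCI-H226 cells (Homo sapiens) for inhibition, read by MTT assay, with a stated time of 48 h, tested at 10 uM (a lower number here means less inhibition, a higher number more inhibition at the concentration tested (going by the name of the read-out)), compound 3 gives 56.7%. Compound 1 `COc1cc(NC(=O)Nc2cc(Nc3ccc(OC)c(C)c3)ncn2)cc(OC)c1` gives 39.7% and compound 2 `CCc1cccc(Nc2cc(NC(=O)Nc3cc(OC)cc(OC)c3)ncn2)c1` gives 36.7%. The steps of a number 17 percentage points higher from compound 1 to compound 3 (beyond the scatter) and a number 20 percentage points higher from compound 2 to compound 3 (beyond the scatter) both lie beyond the scatter, whereas a number 3 percentage points lower from compound 1 to compound 2 (within the scatter) lies within it, so compound 1 and compound 2 cannot be ordered against each other.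

Compound 4 `CCc1ccc(Nc2cc(NC(=O)Nc3cc(OC)cc(OC)c3)ncn2)cc1` is not yet measured. Its change from compound 3 is 4-ethylphenyl in place of 5-iodo-2-methoxyphenyl on a nitrogen on an aromatic ring. Within the data shown here, two measured steps bear on this: a number 20 percentage points higher from compound 2 to compound 3 (beyond the scatter) and a number 17 percentage points higher from compound 1 to compound 3 (beyond the scatter). The move to compound 4 runs in the reverse sense of both, removing the 5-iodo-2-methoxyphenyl and bringing in an ethylphenyl, and compound 2 with its 3-ethylphenyl is the closest measured analogue. The expectation is therefore a drop of roughly the size seen from compound 2 to compound 3, back toward the level of compound 2, and the step of a number 18.7 percentage points lower from compound 3 to compound 4 (beyond the scatter) is what is expected. Among the measured compounds shown here, no measured pair compares 4-ethylphenyl with 3-ethylphenyl directly, which widens the uncertainty. Compound 4 is estimated at 38%, with a range from 25% to 52%.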

Compound 4, a percentage reported as inhibition, at one concentration (the size of the read-out at that concentration, not a potency): 50.1%
Compound 4: middle estimate off by 12.1 percentage points, on the low side; measured number inside the range.
By their numbers in this assay, from the lowest: compounds 2 and 1 (each within the scatter of the next); then compounds 4 and 3 (each within the scatter of the next).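

In this assay the step is a number 6.6 percentage points lower from compound 3 to compound 4 (within the scatter), so on this nitrogen the 4-ethylphenyl group, made of carbon only, cannot be told apart from the 5-iodo-2-methoxyphenyl group, and a reading at this level does not depend on having the iodine and the methoxy group. Where the ethyl group sits does count in this pair of compounds: with 4-ethylphenyl in place of 3-ethylphenyl the step is a number 13.4 percentage points higher from compound 2 to compound 4 (beyond the scatter), and with 4-ethylphenyl in place of 4-methoxy-3-methylphenyl it is a number 10.4 percentage points higher from compound 1 to compound 4 (beyond the scatter), which puts compound 3 and compound 4 in a group apart from compound 1 and compound 2 on this one pair of steps and the earlier steps. No measured evidence explains these readings.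

The compounds shown leave open whether the level seen with 4-ethylphenyl carries over to a longer chain at the same place, such as 4-butylphenyl, or to a ring bearing an amine or a carboxylic acid. They also leave open how the iodine and the methoxy group of compound 3 each act alone, as in 2-methoxyphenyl, and all of these readings stand at one concentration, so they give no potency.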